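A few compounds are considered here, and "the series" means these few. Any claim that something is new, unique, unknown or untested is made for them only; others in the source may bear on it.

Two compounds share one core and differ only in the chain on it. Compound 1 `CCCCCCOc1ccc(-n2cnnc2CCC)cc1` gives 5.7 mg/kg in a functional assay on the whole organism (strain C57B/6) with Mus musculus as the target, in the maximal electroshock model (on this read-out higher numbers stand for an effect only at larger amounts of compound and lower numbers for an effect already at smaller amounts), and compound 2 `CCCCCCOc1ccc(-n2cnnc2CCCCC)cc1` gives 32.8 mg/kg. Going by the values given here, on these two numbers compound 2 stands highest, with compound 1 as its only neighbour: a 5.8-fold higher number from compound 1 to compound 2 (0.76 log units; beyond the scatter).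

Compound 3 `CCCCCCOc1ccc(-n2cnnc2-c2ccc(F)cc2)cc1` is not yet measured. Its change from compound 2 is 4-fluorophenyl in place of pentyl on an aromatic carbon. Among the compounds with values here, no measured step swaps a chain for an aromatic ring, so the one step known, a 5.8-fold higher number from compound 1 to compound 2 (0.76 log units; beyond the scatter), only shows that a longer chain moved the number up and cannot tell how a 4-fluorophenyl will act in its place. The expected step is therefore small and uncertain: a 2.2-fold lower number from compound 2 to compound 3 (0.34 log units; beyond the scatter).

For compound 3 the estimate in this assay is 15 mg/kg, with a likely range from 4 mg/kg to 60 mg/kg.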

Compound 3, dose for half-maximal effect: 22 mg/kg
Estimate against measurement, compound 3: 1.5-fold (0.17 log units) below, within the range that was stated.
By their numbers in this assay, from the lowest: compound 1; then compounds 3 and 2 (each within the scatter of the next).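

At this aromatic carbon an aromatic ring can replace a chain with no readable effect: in this assay the swap from pentyl to 4-fluorophenyl gives a 1.5-fold lower number from compound 2 to compound 3 (0.17 log units; within the scatter) and so leaves the two compounds indistinguishable. Set against the shorter chain, the same ring gives a 3.9-fold higher number from compound 1 to compound 3 (0.59 log units; beyond the scatter) and so, like pentyl, it stands apart from propyl, which leaves compound 1 needing the smallest dose of the three. Nothing available explains why two such different groups give readings this close.

On these data alone, whether the fluorine contributes anything remains open, and a plain phenyl at this carbon would separate its part from that of the ring. Also open, as far as these compounds go, is how a butyl chain, an ethyl chain or a pyridine ring would read here, and whether propyl sits near the best point or only happens to beat pentyl.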